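Methoxy count on the benzylic aryl: compound 3 to compound 4

This account rests on a few compounds, and the source may have more. Where it says the series, first, only, none or still open, it means among the compounds named here.

The series shares one core. Compound 1 `COc1cc(Cn2cc(CNC(=O)c3cn(-c4ccccc4)nc3-c3ccccc3)nn2)cc(OC)c1OC` carries a 3,4,5-trimethoxyphenyl on the saturated chain carbon bound to the aromatic nitrogen, compound 2 `O=C(NCc1cn(Cc2ccc(F)cc2)nn1)c1cn(-c2ccccc2)nc1-c1ccc(Cl)cc1` a 4-fluorophenyl there, and compound 3 `COc1ccc(Cn2cc(CNC(=O)c3cn(-c4ccccc4)nc3-c3ccc(Cl)cc3)nn2)cc1OC` a 3,4-dimethoxyphenyl. In a functional assay on MCF7 cells (Homo sapiens) for antiproliferative activity, read by sulforhodamine B assay, with a stated time of 48 h (a lower number here means a stronger inhibitor of growth, a higher number a weaker inhibitor of growth), compound 2 gives 570 nM. Compound 3 reaches only the limit of this assay, > 100000 nM. Compound 1 also sits at that limit, > 100000 nM. Among the measured compounds shown here, the single step measured between neighbours, an at least 170-fold higher number from compound 2 to compound 3 (2.24 log units; beyond the scatter), is large, and its size is set by the limit of > 100000 nM in this assay, at which 2 of the 3 values shown sit, where two of the three values rest.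

Compound 4 `COc1cc(Cn2cc(CNC(=O)c3cn(-c4ccccc4)nc3-c3ccc(Cl)cc3)nn2)cc(OC)c1OC` is the next member: methoxy in place of hydrogen on an aromatic carbon. For the measured compounds named here, no measured step bears directly on this change. The nearest points are compound 3 at its limit and compound 1, which already holds the trimethoxy pattern and sits at the same limit. The expectation is therefore that compound 4 shows no step beyond the scatter, a number no higher from compound 3 to compound 4 (the limit leaves the size open), and stays at the limit in this assay. Compound 4 is estimated at 100000 nM, within 30000 nM to 300000 nM.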

Compound 4, concentration for 50% growth inhibition: 2500 nM
The estimate for compound 4 lay 40-fold (1.60 log units) above the measured number, and the stated range ends above it.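

In this assay, methoxy in place of hydrogen on the aromatic carbon ortho to a methoxy group carries the 4-chlorophenyl member off the limit, with an at least 40-fold lower number from compound 3 to compound 4 (1.60 log units; beyond the scatter), so on this benzylic aryl an added methoxy does not push the number further up, and the step runs opposite to the one seen on going from 4-fluorophenyl to 3,4-dimethoxyphenyl. The 3,4,5-trimethoxyphenyl group is also not tied to the limit, since chloro in place of hydrogen on an aromatic carbon of the other aryl gives an at least 40-fold lower number from compound 1 to compound 4 (1.60 log units; beyond the scatter), which makes the reading of this group depend on that chloro. Set against the 4-fluorophenyl member, the trimethoxy pattern gives only a modest change, a 4.4-fold higher number from compound 2 to compound 4 (0.64 log units; beyond the scatter), and the two steps that start from the limit fix only the least possible size: the limit of > 100000 nM in this assay, at which 2 of the 4 values shown sit.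

As far as these compounds go, whether chloro in place of hydrogen acts in the same way on the 3,4-dimethoxyphenyl member stays open. Also open, from the compounds shown here alone, is whether an ethoxy or a hydroxy in place of the added methoxy would hold the gain.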